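A few compounds are considered here, and "the series" means these few. Any claim that something is new, unique, unknown or untested is made for them only; others in the source may bear on it.

Measured so far:
compound 1 `COc1ncnc2c1c(-c1ccsc1)cn2[C@@H]1O[C@H](CO)[C@@H](O)[C@H]1O`, 90 nM
compound 2 `COc1nc(N)nc2c1c(-c1ccsc1)cn2[C@@H]1O[C@H](CO)[C@@H](O)[C@H]1O`, > 20000 nM

Going by the values given here, in a functional assay on K562 cells (Homo sapiens), read by MTT assay, with a stated time of 72 h (a lower number here means a stronger inhibitor, a higher number a weaker inhibitor), compound 1 gives 90 nM, the only plain number among the values shown. Compound 2 is reported only as a limit of the assay, > 20000 nM, and that limit is the limit of > 20000 nM in this assay, at which 1 of the 2 values shown sits. The step of an at least 220-fold higher number from compound 1 to compound 2 (2.34 log units; beyond the scatter) describes a different change from the one followed here, so it gives no direct guide. Compound 3 `CSc1ncnc2c1c(-c1ccsc1)cn2[C@@H]1O[C@H](CO)[C@@H](O)[C@H]1O` differs from compound 1 by methylsulfanyl in place of methoxy on an aromatic carbon. Among the compounds with values here, no measured step covers this exchange; the two groups match in what is counted, and nothing in the data points to a change beyond the scatter. Compound 3 is therefore expected to give about 60 nM in this assay, with a likely range from 15 nM to 300 nM. This expectation amounts to an estimated step of a 1.5-fold lower number from compound 1 to compound 3 (0.18 log units; within the scatter), within the scatter.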

Compound 3, half-maximal inhibitory concentration: 450 nM
For compound 3 the middle estimate is 7.5-fold (0.88 log units) below the measured one; the measured number lies above the stated range.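

In this assay the exchange of methoxy for methylsulfanyl gives a 5.0-fold higher number from compound 1 to compound 3 (0.70 log units; beyond the scatter) and so shows that this position responds to a change from oxygen to sulfur. The earlier step concerned a different place on the shared core, so it said nothing about this position. The step appears even though the two groups match in heavy atoms, hydrogen-bond donors and hydrogen-bond acceptors, and nothing measured here accounts for it.

Going by these compounds, with only methoxy and methylsulfanyl at this position, it remains open how an amine, a hydroxyl group or a longer chain such as ethoxy would fare. Also open, on these data alone, is whether the exchange of methoxy for methylsulfanyl would give a step of similar size on a core carrying the amino group of compound 2.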